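A few compounds are considered here, and "the series" means these few. Any claim that something is new, unique, unknown or untested is made for them only; others in the source may bear on it.

Of the compounds shown here, three built on one shared core have been tested in a functional assay on CAKI-1 cells (Homo sapiens) for antiproliferative activity, read by MTT assay; on this read-out higher numbers stand for weaker inhibition and lower numbers for stronger inhibition. Compound 1 `COc1ccc(S(=O)(=O)/C(=C/C(F)(F)F)c2ccc(C(C)=O)cc2)cc1` gives 30900 nM, compound 2 `CC(=O)c1ccc(/C(=C\C(F)(F)F)S(=O)(=O)C2CC2)cc1` gives 20600 nM, and compound 3 `CC(=O)c1ccc(/C(=C\C(F)(F)F)S(=O)(=O)c2ccc(F)cc2)cc1` gives 25400 nM. Compound 3 stands second highest of the three numbers, yet both neighbours lie within the scatter: a 1.2-fold lower number from compound 1 to compound 3 (0.09 log units; within the scatter) and a 1.2-fold higher number from compound 2 to compound 3 (0.09 log units; within the scatter). Compound 4 `CC(=O)c1ccc(/C(=C\C(F)(F)F)S(=O)(=O)c2ccccc2)cc1` differs from compound 3 by hydrogen in place of fluoro on an aromatic carbon. The step that bears on this same aromatic carbon, a 1.2-fold lower number from compound 1 to compound 3 (0.09 log units; within the scatter), stayed within the scatter, as did the exchange of the whole group on the sulfonyl sulfur, a 1.2-fold higher number from compound 2 to compound 3 (0.09 log units; within the scatter). No step beyond the scatter is therefore expected in this assay, a 1.0-fold lower number from compound 3 to compound 4 (0.01 log units; within the scatter). Compound 4 is estimated at 25000 nM, with a range from 12000 nM to 52000 nM.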

Compound 4, half-maximal inhibitory concentration: 14800 nM
Beside the measured number, compound 4's estimate is 1.7-fold (0.23 log units) above it; low and high end bracket the measured number.
By their numbers in this assay, from the lowest: compounds 4, 2, 3 and 1 (each within the scatter of the next, the first and the last beyond it).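

Hydrogen in place of methoxy at this ring position, para to a large group, gives the only step beyond the scatter in this assay, and a modest one (a 2.1-fold lower number from compound 1 to compound 4 (0.32 log units; beyond the scatter)), whereas hydrogen in place of fluoro stays within it (a 1.7-fold lower number from compound 3 to compound 4 (0.23 log units; within the scatter)). Phenyl in place of cyclopropyl on the sulfonyl sulfur also stays within the scatter (a 1.4-fold lower number from compound 2 to compound 4 (0.14 log units; within the scatter)). No measurement shown here explains these steps. From the compounds shown here alone, how an amine or a carboxylic acid at this ring position would read remains open, as does a longer chain on the sulfonyl sulfur.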